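A few compounds are considered here, and "the series" means these few. Any claim that something is new, unique, unknown or untested is made for them only; others in the source may bear on it.

In a functional assay on HepG2 cells (Homo sapiens) for inhibition, read by MTT assay, with a stated time of 24 h (on this read-out higher numbers stand for weaker inhibition and lower numbers for stronger inhibition), compound 1 (`CC1(C)[C@H]2CC[C@]1(C)N(Cc1cn(-c3ccccc3Br)nn1)C(=O)C2`) gives 150 nM and compound 2 (`CC1(C)[C@H]2CC[C@]1(C)N(Cc1cn(-c3ccc(C#N)cc3)nn1)C(=O)C2`) gives 50 nM while compound 3 (`CC1(C)[C@H]2CC[C@]1(C)N(Cc1cn(-c3ccccc3C#N)nn1)C(=O)C2`) gives 180 nM on the same scale. Compound 3 therefore sits level with compound 1 at the weaker end of this small set. The step of a 1.2-fold higher number from compound 1 to compound 3 (0.08 log units; within the scatter) keeps those two together, and the step of a 3.6-fold higher number from compound 2 to compound 3 (0.56 log units; beyond the scatter) places compound 3 behind compound 2.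

The next structure is compound 4 (`CC1(C)[C@H]2CC[C@]1(C)N(Cc1cn(-c3ccccc3)nn1)C(=O)C2`), which has hydrogen in place of cyano on an aromatic carbon, ortho to a large group, so that 2-cyanophenyl becomes phenyl. In counted terms the change is hydrogen in place of cyano on an aromatic carbon at that one place.

Going by the values given here, no measured step removes a group from that place, so the evidence is indirect. The closest guide is the exchange of bromo for cyano between compound 1 and compound 3, which stayed within the scatter. The two larger steps, a 3.0-fold lower number from compound 1 to compound 2 (0.48 log units; beyond the scatter) and a 3.6-fold higher number from compound 2 to compound 3 (0.56 log units; beyond the scatter) alike, involve the 4-cyanophenyl group of compound 2, which compound 4 lacks.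

A small change in this assay is thus expected, with no shift beyond the scatter and at most a slight drift towards a lower number. The expected step is a 1.4-fold lower number from compound 3 to compound 4 (0.14 log units; within the scatter) and no more. Compound 4 is estimated at 130 nM with an expected range from 55 nM to 300 nM in this assay.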

Compound 4, half-maximal inhibitory concentration: 90 nM
Compound 4: the middle estimate sits 1.4-fold (0.16 log units) above what was measured; the measured number falls inside the stated range.
By their numbers in this assay, from the lowest: compounds 2, 4, 1 and 3 (each within the scatter of the next, the first and the last beyond it).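

Going by these compounds alone, with hydrogen on the aromatic carbon ortho to a large group, compound 4 gives the first reading of this place without a substituent, and in this assay the result is a 2.0-fold lower number from compound 3 to compound 4 (0.30 log units; within the scatter), so taking away the cyano group leaves the number within the scatter. Hydrogen in place of bromo at the same carbon gives the same picture, with a 1.7-fold lower number from compound 1 to compound 4 (0.22 log units; within the scatter), so neither bromo nor cyano is needed there for a number in this range. Compound 4 also cannot be separated from the compound with the lowest number, as a 1.8-fold higher number from compound 2 to compound 4 (0.26 log units; within the scatter) shows, even though a 3.6-fold higher number from compound 2 to compound 3 (0.56 log units; beyond the scatter) still separates the two ends of the set, so the unsubstituted phenyl lies level with both ends rather than marking a distinct tier.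

No measurement bearing on why these numbers fall as they do accompanies the compounds shown. On these data alone, only hydrogen, bromo and cyano appear at this carbon on the shared core, so it remains open whether an amine, a carboxylic acid or a longer chain there would stay within the same band.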